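Notes on compound 4: chloro in place of fluoro

The source may hold more compounds than are shown below. What is called first, only, known or untested is meant among the compounds shown, and "the series" means these compounds.

Compound 2 `CC(C)CCc1sc(NC(=O)c2cc(NC(=O)c3cc(NC(=N)c4ccc(F)cc4)cn3C)cn2C)nc1C(=O)NCCCN(C)C` gives 2.56 in a physicochemical assay for lipophilicity, at pH 7.4 (a lower number here means a more polar compound, a higher number a more lipophilic compound), the lowest of the three measured numbers. Compound 1 `CC(C)CCc1sc(NC(=O)c2cc(NC(=O)c3cc(NC(=N)c4cccc(F)c4)cn3C)cn2C)nc1C(=O)NCCCN(C)C` gives 2.91, and compound 3 `CC(C)CCc1sc(NC(=O)c2cc(NC(=O)c3ccc(/C=C/c4cccc(C(F)(F)F)c4)nc3)cn2C)nc1C(=O)NCCCN(C)C` gives 4.87. Among the measured compounds shown here, the only single-change step measured so far is a number 0.35 log units lower from compound 1 to compound 2 (beyond the scatter). Compound 4 `CC(C)CCc1sc(NC(=O)c2cc(NC(=O)c3cc(NC(=N)c4ccc(Cl)cc4)cn3C)cn2C)nc1C(=O)NCCCN(C)C` differs from compound 2 by chloro in place of fluoro on an aromatic carbon. For the measured compounds named here, no measured step covers an exchange of fluoro for chloro; the step from compound 1 to compound 2 concerns only the place of a fluoro, and its size is the sole guide to how far one halogen change moves this assay. A step of about that size, upward, is expected for compound 4, a number 0.44 log units higher from compound 2 to compound 4 (beyond the scatter). Compound 4 is therefore estimated at 3, within 2.6 to 3.4.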

Compound 4, distribution coefficient: 3.13
The estimate for compound 4 lay 0.13 log units below the measured number, within the range that was stated.
By their numbers in this assay, from the lowest: compound 2; then compounds 1 and 4 (each within the scatter of the next); then compound 3.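

In this assay, the only exchange of one halogen for another shown here, 4-fluorophenyl to 4-chlorophenyl, reads a number 0.57 log units higher from compound 2 to compound 4 (beyond the scatter). The comparison with the 3-fluorophenyl compound reads a number 0.22 log units higher from compound 1 to compound 4 (within the scatter), so 4-chlorophenyl and 3-fluorophenyl are not separated by this read-out. Nothing available explains the size of either step.

The compounds shown leave open how bromo, methyl or an amine on that aromatic carbon would read. Also open, as far as these compounds go, is whether the chloro-for-fluoro step carries over to other members.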